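Rearranged ring fusion on the urea aryl group

The compounds below may be only part of what the source reports. "The series", "measured", "known", "first", "only" and "open" are said of these compounds alone.

Among the compounds with values here, compound 2 `CN(C)C1(Cc2ccccc2)CCN(c2cc(C(F)(F)F)ccc2CNC(=O)Nc2cccc3[nH]c(=O)ccc23)CC1` stands as the lower of the two numbers so far in an assay on CHO cells for displacement of a labelled ligand from transient receptor potential cation channel subfamily V member 1 (Homo sapiens), read by scintillation counting, with a stated time of 60 min (on this read-out lower numbers stand for stronger inhibition and higher numbers for weaker inhibition), giving 1.67 nM, while compound 1 `CN(C)C1(Cc2ccccc2)CCN(c2cc(C(F)(F)F)ccc2CNC(=O)Nc2ccc(NS(C)(=O)=O)c(F)c2)CC1` gives 1160 nM. Within the data shown here, the single measured step, a 690-fold lower number from compound 1 to compound 2 (2.84 log units; beyond the scatter), shows that the group on the amide-type nitrogen governs much of the read-out. Compound 3 `CN(C)C1(Cc2ccccc2)CCN(c2cc(C(F)(F)F)ccc2CNC(=O)Nc2cccc3c(=O)[nH]ccc23)CC1` keeps the same atoms as compound 2, joined differently: a group of 11 heavy atoms (9 carbon, 1 nitrogen, 1 oxygen; one six-membered aromatic ring of carbon only, one six-membered aromatic ring with 1 hetero atom) in place of a group of 11 heavy atoms (9 carbon, 1 nitrogen, 1 oxygen; one six-membered aromatic ring of carbon only, one six-membered aromatic ring with 1 hetero atom), on an amide-type nitrogen, so the hydrogen-bond donor and acceptor of the bicyclic group sit in new places. Among the measured compounds shown here, no measured pair shows a rearrangement of this kind, so the earlier step bears on it only by showing that this region is sensitive. The author expects compound 3 to give a somewhat higher number than compound 2, a step of a 7.2-fold higher number from compound 2 to compound 3 (0.86 log units; beyond the scatter) in this assay, with real uncertainty about its size. Compound 3 is therefore estimated at 12 nM, between 2 nM and 80 nM.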

Compound 3, inhibition constant: 111 nM
For compound 3 the middle estimate is 9.3-fold (0.97 log units) below the measured one, and the stated range ends below it.
By their numbers in this assay, from the lowest: compound 2; then compound 3; then compound 1.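

Rejoining the same atoms within the bicyclic group gives a 66-fold higher number from compound 2 to compound 3 (1.82 log units; beyond the scatter) in this assay, so the read-out at this position depends on how the atoms are arranged, not only on which atoms and how many donors and acceptors are present. The rearranged group still gives a 10-fold lower number from compound 1 to compound 3 (1.02 log units; beyond the scatter), which places compound 3 in the middle of the series and shows that the two bicyclic arrangements are far from equivalent, although both give lower numbers than the group of compound 1. No measurement here explains this difference between the two arrangements.

The compounds shown leave open whether the ring amide hydrogen or the carbonyl accounts for the gap, a question that a methyl group on the ring nitrogen or an amine in place of the carbonyl could address. They also leave open whether the same order of these bicyclic groups holds when the benzyl or dimethylamino group on the shared core is replaced.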